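Cyclopropyl in place of butyl at the ring amine

The source may report more compounds than this note shows. Statements on the series, on what has been measured and on what is new or still open speak of the compounds shown alone.

Of the compounds shown here, three built on one shared core have been measured in an assay on isolated protein for binding affinity to adenosine receptor A1 (Bos taurus); a lower number here means a stronger inhibitor, a higher number a weaker inhibitor. Compound 1 `c1ccc(Cn2nnc3c(NC4CCCC4)nc(-c4ccccc4)nc32)cc1` carries a cyclopentyl group on a nitrogen on an aromatic ring and gives 11000000 nM in this assay. Compound 2 `O[C@H]1CCCC[C@@H]1Nc1nc(-c2ccccc2)nc2c1nnn2Cc1ccccc1`, with 2-hydroxycyclohexyl in that place, gives 10300000 nM in this assay. Compound 3 `CCCCNc1nc(-c2ccccc2)nc2c1nnn2Cc1ccccc1`, with butyl there, gives 11000000 nM in this assay. The steps among them are a 1.1-fold lower number from compound 1 to compound 2 (0.03 log units; within the scatter), no change at the digits printed from compound 1 to compound 3 (within the scatter) and a 1.1-fold higher number from compound 2 to compound 3 (0.03 log units; within the scatter); each lies within the scatter, so the three numbers cannot be told apart, and compound 3 sits level with compound 1 and with compound 2.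

Compound 4 `c1ccc(Cn2nnc3c(NC4CC4)nc(-c4ccccc4)nc32)cc1` differs from compound 3 by cyclopropyl in place of butyl on a nitrogen on an aromatic ring. Within the data shown here, the steps that bear on this change are those that alter the same group: no change at the digits printed from compound 1 to compound 3 (within the scatter) and a 1.1-fold lower number from compound 1 to compound 2 (0.03 log units; within the scatter). Neither moved the number beyond the scatter, whether the group was a ring or a chain, with or without a hydroxyl. Nothing among these three compounds points to a shift when a three-membered ring replaces the chain. Compound 4 is therefore expected to stay where compound 3 is, with an expected step of no change at the digits printed from compound 3 to compound 4 (within the scatter). In this assay compound 4 is estimated at 11000000 nM, expected to fall between 4000000 nM and 30000000 nM.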

Compound 4, inhibition constant: 11000000 nM
Compound 4: the middle estimate sits on the measured number at the digits printed, and the stated range covers the measured number.
By their numbers in this assay, from the lowest: compounds 2, 1, 3 and 4 (each within the scatter of the next).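

Working notes on the ring amine: in this assay, a three-membered ring of carbon at this nitrogen on an aromatic ring reads the same as the four-carbon chain it replaces (no change at the digits printed from compound 3 to compound 4 (within the scatter)). It also cannot be told apart from the two larger rings, with cyclopentyl (no change at the digits printed from compound 1 to compound 4 (within the scatter)) and with 2-hydroxycyclohexyl (a 1.1-fold higher number from compound 2 to compound 4 (0.03 log units; within the scatter)). The level reading at this place therefore now covers cyclopropyl as well as butyl, cyclopentyl and 2-hydroxycyclohexyl, so across these four compounds neither the presence of a ring, nor its size, nor the hydroxyl separates one compound from another. Nothing available explains why the numbers stay level.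

Open, on these data alone, is whether an amine or a carboxylic acid on the chain, or a longer chain such as octyl, would move the number beyond the scatter at this place. As far as these compounds go, all four compounds differ only at this nitrogen, so it also remains open whether the level reading would hold with a change elsewhere on the shared core.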